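Base change on the sugar carbon: compound 2 to compound 4

A few compounds are considered here, and "the series" means these few. Any claim that something is new, unique, unknown or untested is made for them only; others in the source may bear on it.

Of the compounds shown here, three have been measured. In an ADME assay on MRC5 cells (Homo sapiens) for antiproliferative activity, read by sulforhodamine B assay, with a stated time of 72 h (on this read-out higher numbers stand for weaker inhibition and lower numbers for stronger inhibition), compound 2 `CC(C)C[C@H](O)C(=O)NS(=O)(=O)OC[C@H]1O[C@@H](n2cnc3c(N)ncnc32)[C@H](O)[C@@H]1O` gives 16700 nM, the only result reported as a number. For compound 1 `CC(C)[C@@H](O)[C@H](O)C(=O)NS(=O)(=O)OC[C@H]1O[C@@H](n2cnc3c(N)ncnc32)C[C@@H]1O` the result in this assay is a limit, > 20000 nM. For compound 3 `CO[C@H](C(=O)NS(=O)(=O)OC[C@H]1O[C@@H](n2cnc3c(N)nc(Cl)nc32)[C@H](O)[C@@H]1O)[C@H](OC)C(C)C` the result in this assay is likewise a limit, > 20000 nM. Compound 2 therefore stands as the single numerical point, itself close to the limit of > 20000 nM in this assay, at which 2 of the 3 values shown sit. Within the data shown here, no two measured compounds differ in one place, so no measured step is available for calibration.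

Compound 4 `CC(C)C[C@H](O)C(=O)NS(=O)(=O)OC[C@H]1O[C@@H](n2cnc3c(=O)[nH]cnc32)[C@H](O)[C@@H]1O` differs from compound 2 by a group of 10 heavy atoms (5 carbon, 4 nitrogen, 1 oxygen; one five-membered aromatic ring with 2 hetero atoms, one six-membered aromatic ring with 2 hetero atoms) in place of a group of 10 heavy atoms (5 carbon, 5 nitrogen; one five-membered aromatic ring with 2 hetero atoms, one six-membered aromatic ring with 2 hetero atoms), on a saturated ring carbon. The change sits on a saturated ring carbon of the five-membered non-aromatic ring with one oxygen, next to the ring oxygen.

Since compound 2 in this assay already gives 16700 nM, the expected step of a 1.3-fold higher number from compound 2 to compound 4 (0.12 log units; within the scatter) is small, within the scatter, with the weak side somewhat more likely. Compound 4 is expected to give 22000 nM in this assay, between 9000 nM and 50000 nM, and a limit rather than a number would not surprise.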

Compound 4, half-maximal inhibitory concentration: > 20000 nM
Compound 4: no number, only a limit; the forecaster's own chance of this, stated with the estimate: 65%; the middle value does not contradict the limit.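

In this assay, among these compounds, the first step at this position, on a saturated ring carbon next to the ring oxygen, is an at least 1.1-fold higher number from compound 2 to compound 4 (0.07 log units; that floor lies within the scatter). Compound 4 gives a limit, not a number, so the step is a floor only, and it shows no difference between the two groups beyond the scatter. With this result, compound 2 remains the only numerical value, and the series gathers at the ceiling of this assay: the limit of > 20000 nM in this assay, at which 3 of the 4 values shown sit.

Going by these compounds, how far the number rises with this change stays open, as does whether any replacement at this place can move it toward stronger inhibition. A group of another kind here, such as one carrying a carboxylic acid, remains unplaced in this series.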